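Hydrazone aryl variation in the shared core: acetoxy-methoxyphenyl analogue

The source may report more compounds than this note shows. Statements on the series, on what has been measured and on what is new or still open speak of the compounds shown alone.

Compound 3 `CC(C)c1ccc(/C=N/NC(=O)CCN2CCN(c3ccnc4cc(Cl)ccc34)CC2)cc1` gives 7900 nM in an ADME assay on cells (Splenocyte, Mus musculus, strain BALB/c) for cytotoxicity, read by thymidine incorporation, with a stated time of 24 h (on this read-out lower numbers stand for stronger inhibition and higher numbers for weaker inhibition), the lowest of the two numbers in hand; its nearest neighbour is compound 1 `O=C(CCN1CCN(c2ccnc3cc(Cl)ccc23)CC1)N/N=C/c1ccc([N+](=O)[O-])cc1`, which gives 12100 nM, so the step of a 1.5-fold lower number from compound 1 to compound 3 (0.19 log units; within the scatter) stays within the scatter. Compound 2 `O=C(CCN1CCN(c2ccnc3cc(Cl)ccc23)CC1)N/N=C/c1cccc(Cl)c1` gives > 100000 nM, which is a limit of the assay and not a number. That value sits at the limit of > 100000 nM in this assay, at which 1 of the 3 values shown sits. The step of an at least 12-fold lower number from compound 2 to compound 3 (1.10 log units; beyond the scatter) and the step of an at least 8.2-fold higher number from compound 1 to compound 2 (0.91 log units; beyond the scatter) show that exchange of the aryl group on the hydrazone carbon can move this read-out beyond the scatter.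

Compound 4 `COc1cc(/C=N/NC(=O)CCN2CCN(c3ccnc4cc(Cl)ccc34)CC2)ccc1OC(C)=O` carries the change (4-acetoxy-3-methoxyphenyl in place of 4-isopropylphenyl on a carbon with a double bond to nitrogen). Going by the values given here, no measured step covers an acetoxy or methoxy group; the only bearing steps are those above, where a nitro analogue matched the isopropyl compound and a chloro analogue fell beyond the limit. A modest rise is therefore expected, a 1.9-fold higher number from compound 3 to compound 4 (0.28 log units; within the scatter), with wide uncertainty toward the limit. For compound 4 the estimate is 15000 nM, within 4000 nM to 60000 nM.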

Compound 4, half-maximal inhibitory concentration: 15800 nM
Beside the measured number, compound 4's estimate is 1.1-fold (0.02 log units) below it; measured number inside the range.
By their numbers in this assay, from the lowest: compounds 3, 1 and 4 (each within the scatter of the next). At a limit, above all of these: compound 2.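

The 4-acetoxy-3-methoxyphenyl group, with 12 heavy atoms and 3 hydrogen-bond acceptors, stays within the scatter of both measured comparators: a 2.0-fold higher number from compound 3 to compound 4 (0.30 log units; within the scatter) and a 1.3-fold higher number from compound 1 to compound 4 (0.12 log units; within the scatter). Going by these compounds alone, at this carbon, compounds 1, 3 and 4 therefore form one band despite their different aryl groups, and a third aryl group now sits in that band, with compound 2 the one compound against this pattern. The step of an at least 6.3-fold lower number from compound 2 to compound 4 (0.80 log units; beyond the scatter) rests on a limit and not on a number, and compound 2 alone stands there: the limit of > 100000 nM in this assay, at which 1 of the 4 values shown sits.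

With both groups entering together, the separate contributions of acetoxy and methoxy cannot be read. Going by these compounds, what an aminophenyl or carboxyphenyl group would give at this carbon also stays open, as does whether any aryl group falls clearly below this band.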